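A few compounds are considered here, and "the series" means these few. Any claim that something is new, unique, unknown or untested is made for them only; others in the source may bear on it.

Working notes on the series. The shared core carries a (methoxycarbonyl)methyl group and a cyclic amine on the carbon with a double bond to nitrogen; the measured set is compound 1 `COC(=O)CC1c2ccccc2N=C(N2CCOCC2)N1c1ccccc1`, compound 2 `COC(=O)CC1c2ccccc2N=C(N2CCN(C)CC2)N1c1ccccc1` and compound 3 `COC(=O)CC1c2ccccc2N=C(N2CCCCC2)N1C1CCCCC1`. In a functional assay on cells (Oocyte) for inhibition of Voltage-dependent T-type calcium channel subunit alpha-1H (Homo sapiens), tested at 100 uM (a lower number here means less inhibition, a higher number more inhibition at the concentration tested (going by the name of the read-out)), compound 1 gives 14%, and compound 2 gives 15%; the step of a number 1 percentage points higher from compound 1 to compound 2 (within the scatter) is within the scatter. Compound 3 gives 27% in this assay and stands highest of the three, beyond the scatter from both compound 2 and compound 1. Compound 3 differs from those two in two places at once, so its two values show only that the pairing of piperidin-1-yl with cyclohexyl sits higher; no single step accounts for it.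

The next compound is compound 4 `COC(=O)CC1c2ccccc2N=C(N2CCOCC2)N1C1CCCCC1`, which keeps the cyclohexyl group and differs from compound 3 by morpholin-4-yl in place of piperidin-1-yl on a carbon with a double bond to nitrogen. Within the data shown here, no measured step changes piperidin-1-yl to morpholin-4-yl. Among the measured compounds shown here, the one step that bears on a change of the amine ring is a number 1 percentage points higher from compound 1 to compound 2 (within the scatter), which stayed within the scatter, so the expectation for this assay is a step of a number 5 percentage points lower from compound 3 to compound 4 (within the scatter) from compound 3, within the scatter or at most a small drop. Compound 4 is estimated at 22%, with a range from 8% to 36%.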

Compound 4, a percentage reported as inhibition, at one concentration (the size of the read-out at that concentration, not a potency): 12.2%
Compound 4: the middle estimate sits 9.8 percentage points above what was measured, and the stated range covers the measured number.
By their numbers in this assay, from the lowest: compounds 4, 1 and 2 (each within the scatter of the next); then compound 3.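

With cyclohexyl held constant, the amine on the carbon with a double bond to nitrogen can now be read as a single change: in this assay the step of a number 14.8 percentage points lower from compound 3 to compound 4 (beyond the scatter) ties the higher number of compound 3 to piperidin-1-yl in this cyclohexyl setting, not merely to the pairing of two changes. With morpholin-4-yl held constant, the substituent on the ring amine nitrogen can also be read alone, and the step of a number 1.8 percentage points lower from compound 1 to compound 4 (within the scatter) shows no measurable effect of cyclohexyl in place of phenyl in this morpholin-4-yl setting. So this amine position responds to morpholin-4-yl in place of piperidin-1-yl, whereas the earlier step in the phenyl setting, 4-methylpiperazin-1-yl in place of morpholin-4-yl, did not move the number, and no measurement on hand gives a reason for the difference.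

Going by these compounds, whether piperidin-1-yl raises the number in the phenyl setting as well remains open, as a compound joining phenyl to piperidin-1-yl would be needed to test this. Also open, on these data alone, is how a smaller pyrrolidin-1-yl ring, an open-chain dimethylamino group or a carboxylic acid in place of the methyl ester would read.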